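The source may hold more compounds than are shown below. What is called first, only, known or untested is meant among the compounds shown, and "the series" means these compounds.

Compound 1 `COc1ccc2c(=O)c(/C=C/C(=O)Nc3cc(C)ccc3C)coc2c1` carries the higher of the two numbers in a functional assay on HeLa cells (Homo sapiens) for inhibition, read by MTT assay, with a stated time of 48 h; on this read-out lower numbers stand for stronger inhibition and higher numbers for weaker inhibition; in this assay compound 1 gives 58400 nM. Compound 2 `Cc1ccccc1NC(=O)/C=C/c1coc2cc(O)ccc2c1=O` gives 8670 nM in this assay, a gap from compound 1 that lies beyond the scatter. Compound 3 `COc1cccc(NC(=O)/C=C/c2coc3cc(OC)ccc3c2=O)c1` differs from compound 1 in one place: 3-methoxyphenyl in place of 2,5-dimethylphenyl on an amide-type nitrogen. For the measured compounds named here, no measured pair shows this change, so nothing fixes its size. For compound 3 in this assay a step of a 1.5-fold lower number from compound 1 to compound 3 (0.16 log units; within the scatter) is expected, no larger than the scatter or slightly toward a lower number. Compound 3 is estimated at 40000 nM in this assay, with a range from 12000 nM to 130000 nM.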

Compound 3, half-maximal inhibitory concentration: 19200 nM
For compound 3 the middle estimate is 2.1-fold (0.32 log units) above the measured one; measured number inside the range.
By their numbers in this assay, from the lowest: compound 2; then compound 3; then compound 1.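

The aryl group on the amide-type nitrogen of the shared core is a position that affects the read-out in this assay: 3-methoxyphenyl in place of 2,5-dimethylphenyl gives a 3.0-fold lower number from compound 1 to compound 3 (0.48 log units; beyond the scatter) and keeps the heavy-atom count unchanged. The entering group adds one hydrogen-bond acceptor, but nothing available links that difference to the step.

A single exchange cannot separate the gain of methoxy from the loss of the two methyl groups. From the compounds shown here alone, how an amine or a carboxylic acid on this phenyl ring would read remains open.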